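Replacing the Sulfonamide Link: What the Chain Series Predicts

The compounds below may be only part of what the source reports. "The series", "measured", "known", "first", "only" and "open" are said of these compounds alone.

Compound 2 `CN(C)C(=O)c1cc2cnc(Nc3ccc(S(=O)(=O)NCCCCCN=C=S)cc3)nc2n1C1CCCC1` was tested in a functional assay on A549 cells (Homo sapiens) for inhibition, read by CCK-8 assay, with a stated time of 72 h, tested at 10 uM (a lower number here means a weaker effect, a higher number a stronger effect of the compound at the concentration tested), where compound 2 gives 102%. Compound 1 `CN(C)C(=O)c1cc2cnc(Nc3ccc(S(=O)(=O)NCCCN=C=S)cc3)nc2n1C1CCCC1` gives 102% and compound 3 `CN(C)C(=O)c1cc2cnc(Nc3ccc(S(=O)(=O)NCCCCCCCN=C=S)cc3)nc2n1C1CCCC1` gives 101% in this assay, so compound 2 stands level with compound 1 at the digits shown, the two together the highest of three numbers, with compound 3 the furthest, yet every gap lies within the scatter: no change at the digits printed from compound 1 to compound 2 (within the scatter), a number 1 percentage points lower from compound 1 to compound 3 (within the scatter) and a number 1 percentage points lower from compound 2 to compound 3 (within the scatter).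

Compound 4 `CN(C)C(=O)c1cc2cnc(Nc3ccc(C(=O)NCCCCN=C=S)cc3)nc2n1C1CCCC1` differs from compound 2 on an aromatic carbon of a six-membered aromatic ring of carbon only, para to a large group: a group of 10 heavy atoms (6 carbon, 2 nitrogen, 1 oxygen, 1 sulfur; no ring) in place of a group of 12 heavy atoms (6 carbon, 2 nitrogen, 2 oxygen, 2 sulfur; no ring), on an aromatic carbon. Within the data shown here, none of the measured steps alters the same part, since each of them only lengthens the chain carrying the isothiocyanate, and none of those moved the number beyond the scatter. Among the measured compounds shown here, no measured step therefore speaks for a change in this assay, and compound 4 is expected to stay near compound 2, a number 3 percentage points lower from compound 2 to compound 4 (within the scatter). The estimate for compound 4 is 99%, expected within 88% to 105%.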

Compound 4, a percentage reported as inhibition, at one concentration (the size of the read-out at that concentration, not a potency): 102%
For compound 4 the middle estimate is 3 percentage points below the measured one, and the stated range covers the measured number.
By their numbers in this assay, from the lowest: compounds 3, 1, 2 and 4 (each within the scatter of the next).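

Replacing the sulfonyl link with a carbonyl link on the aromatic carbon is a different kind of change from lengthening the chain, and in this assay it also leaves the read-out in place, with no change at the digits printed from compound 2 to compound 4 (within the scatter) and no change at the digits printed from compound 1 to compound 4 (within the scatter) in the same series. So, at this one concentration, these compounds do not depend on the sulfonyl group for the size of their effect, although the chain length also differs in both steps and the two changes cannot be told apart. No measurement here explains why the read-out holds across this exchange.

Since all four compounds sit level at a single concentration, any difference in potency stays hidden. Also open, as far as these compounds go, is how a urea link, or a chain ending in an amine instead of the isothiocyanate, would behave at this position.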